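Swapping Phenyl for Pyridin-3-yl: What to Expect

The source may hold more compounds than are shown below. What is called first, only, known or untested is meant among the compounds shown, and "the series" means these compounds.

Three compounds that share a 2-(4-hydroxy-6-oxooxan-2-yl)ethyl group on the shared core have been tested in an assay for inhibition of 3-hydroxy-3-methylglutaryl-coenzyme A reductase (Rattus norvegicus); on this read-out lower numbers stand for stronger inhibition and higher numbers for weaker inhibition. Compound 1 `CCOC(=O)c1c(-c2ccccc2)c(C(C)C)n(CC[C@@H]2C[C@@H](O)CC(=O)O2)c1-c1ccc(F)cc1` gives 50 nM. Compound 2 `CCOC(=O)c1c(-c2ccc(C#N)cc2)c(-c2ccc(F)cc2)n(CC[C@@H]2C[C@@H](O)CC(=O)O2)c1C(C)C` gives 280 nM. Compound 3 `CC(C)c1cc(-c2ccccc2)c(-c2ccc(F)cc2)n1CC[C@@H]1C[C@@H](O)CC(=O)O1` gives 347 nM. The numbers for compound 3 and compound 2 fall within the usual scatter of one another, so neither can be placed above the other, whereas compound 1 sits clearly lower, beyond the scatter, than either. Compound 3 therefore stands at the upper end of the numbers seen so far, alongside compound 2.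

Compound 4 `CC(C)c1cc(-c2cccnc2)c(-c2ccc(F)cc2)n1CC[C@@H]1C[C@@H](O)CC(=O)O1` has not yet been tested. It differs from compound 3 in a single place: pyridin-3-yl in place of phenyl on an aromatic carbon. Going by the values given here, no measured pair in this set isolates such a change, so there is no directly comparable step to lean on. Lacking that, the expectation is a step of no real size, with at most a modest move toward a lower number. The step that this estimate means is a 1.4-fold lower number from compound 3 to compound 4 (0.14 log units; within the scatter). In this assay compound 4 is thus expected to give about 250 nM, with a likely range from 80 nM to 800 nM.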

Compound 4, half-maximal inhibitory concentration: 71 nM
The estimate for compound 4 lay 3.5-fold (0.55 log units) above the measured number; the measured number lies below the stated range.
By their numbers in this assay, from the lowest: compounds 1 and 4 (each within the scatter of the next); then compounds 2 and 3 (each within the scatter of the next).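

In this assay, pyridin-3-yl in place of phenyl gives a 4.9-fold lower number from compound 3 to compound 4 (0.69 log units; beyond the scatter), so this aromatic carbon, next to the ring atom that bears a 4-fluorophenyl group, responds to a change in the ring it carries. The change is small on paper: both groups are six-membered aromatic rings with 6 heavy atoms and no net charge, and they differ only in that one ring carbon becomes nitrogen, taking the hydrogen-bond acceptors from 0 to 1, yet that alone moves the number beyond the scatter. Nothing measured here accounts for the size of this step or ties it to any property of the nitrogen.

As far as these compounds go, it stays open whether the nitrogen must sit where it does in pyridin-3-yl, a question that pyridin-2-yl or pyridin-4-yl at the same carbon would address, as would a pyrimidin-5-yl ring with a second nitrogen. From the compounds shown here alone, it is equally open whether the same swap would give a similar step on the ethyl ester-bearing core of compound 1, where the other groups are arranged differently.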